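From fluoro to trifluoromethyl: compound 4 awaits its reading

The compounds below may be only part of what the source reports. "The series", "measured", "known", "first", "only" and "open" are said of these compounds alone.

In a physicochemical assay for solubility, using the shake flask method, in simulated intestinal fluid, measured as kinetic solubility, with a stated time of 2 h, at 25 degrees C, at pH 6.5 (a lower number here means a less soluble compound, a higher number a more soluble compound), compound 3 `Cc1noc(-c2nc(C)c3c(c2N)C(=O)N(Cc2ccc(F)cc2)C3=O)n1` gives < 5000 nM, which is a limit of the assay and not a number. Compound 1 `CCOC(=O)c1nc(C)c2c(c1N)C(=O)N(Cc1ccccc1)C2=O` gives < 5000 nM, which is also a limit. Compound 2 `Cc1nc(C(=O)N(C)C)c(N)c2c1C(=O)N(Cc1ccccc1)C2=O` gives 172000 nM. Among the compounds with values here, the only measured step, an at least 34-fold higher number from compound 1 to compound 2 (1.53 log units; beyond the scatter), is large, but it is a different change, so it offers little guidance here. Compound 4 `Cc1noc(-c2nc(C)c3c(c2N)C(=O)N(Cc2ccc(C(F)(F)F)cc2)C3=O)n1` carries trifluoromethyl in place of the fluoro of compound 3 on an aromatic carbon (trifluoromethyl in place of fluoro on an aromatic carbon). The nearest guide, which includes compound 3, is the limit of < 5000 nM in this assay, at which 2 of the 3 values shown sit, so no step beyond the scatter is expected. The estimated step is a step that the limit leaves unreadable from compound 3 to compound 4. Compound 4 is expected at about 4000 nM, with an estimated range of 1500 nM to 7000 nM. A reading reported only as a limit is the likely outcome.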

Compound 4, solubility: < 5000 nM
Compound 4: no number, only a limit; the forecaster's own chance of this, stated with the estimate: 85%; the middle value is on the limit's open side.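

Compound 3 and compound 4 each give only a limit, not a number, and no step can be read between them. The compounds shown leave open whether swapping fluoro for trifluoromethyl changes the reading at all.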